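Sulfonyl substituent swap on the bis-sulfonamide piperidine series

A few compounds are considered here, and "the series" means these few. Any claim that something is new, unique, unknown or untested is made for them only; others in the source may bear on it.

Three compounds have numbers in a functional assay on MIA PaCa-2 cells (Homo sapiens) for inhibition, read by MTT assay, with a stated time of 7 days; on this read-out lower numbers stand for stronger inhibition and higher numbers for weaker inhibition. Compound 1 `CCOC(=O)[C@@H]1CCCN(S(=O)(=O)c2ccc(S(=O)(=O)N3CCOCC3)cc2)C1` gives 23500 nM in this assay. Compound 2 `CCN(CC)S(=O)(=O)c1ccc(S(=O)(=O)N2CCC[C@@H](C(=O)N(C)C(C)C)C2)cc1` gives 6200 nM in this assay. Compound 3 `CC(C)c1noc(N2CCN(C(=O)[C@@H]3CCCN(S(=O)(=O)c4ccc(S(=O)(=O)NC5CC5)cc4)C3)CC2)n1` gives 1000 nM in this assay, the lowest of the three numbers; its gaps to compound 2 and to compound 1 both lie beyond the scatter, so compound 3 is the most potent of the three.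

Compound 4 `CC(C)c1noc(N2CCN(C(=O)[C@@H]3CCCN(S(=O)(=O)c4ccc(S(=O)(=O)C(C)C)cc4)C3)CC2)n1` differs from compound 3 in one place: isopropyl in place of cyclopropylamino on a sulfonyl sulfur. Going by the values given here, no measured pair in this set shows that change, so its effect is not known; a modest step toward weaker inhibition is expected, a 1.6-fold higher number from compound 3 to compound 4 (0.20 log units; within the scatter), but one close to the scatter. Compound 4 is estimated at 1600 nM in this assay, with a range from 500 nM to 5000 nM.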

Compound 4, half-maximal inhibitory concentration: 70 nM
Compound 4: the middle estimate sits 23-fold (1.36 log units) above what was measured; the whole stated range lies above it.
By their numbers in this assay, from the lowest: compound 4; then compound 3; then compound 2; then compound 1.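

In this assay the sulfonyl sulfur whose other neighbour is the aromatic carbon proves highly sensitive to its substituent, with isopropyl in place of cyclopropylamino giving a 14-fold lower number from compound 3 to compound 4 (1.15 log units; beyond the scatter) as a large step beyond the scatter. The change removes a ring and a hydrogen-bond donor, and the step alone cannot separate these two differences. No evidence on the cause of this step is available.

As far as these compounds go, whether the ring or the donor matters remains open. A cyclopropyl group directly on the sulfonyl sulfur and a dimethylamino group there would separate the two.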